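Longer Sulfur Chains in a Chloromethyl Ketone Series

The source may report more compounds than this note shows. Statements on the series, on what has been measured and on what is new or still open speak of the compounds shown alone.

compound 1, `CCSC[C@H](NC(C)=O)C(=O)CCl`: 99900 nM
compound 2, `CCCSC[C@H](NC(C)=O)C(=O)CCl`: 8000 nM
compound 3, `CCCCCCCCSC[C@H](NC(C)=O)C(=O)CCl`: 4100 nM

All three share one core and differ only in the chain on the sulfur; the numbers come from a functional assay on MOLT-3 cells (Homo sapiens); a lower number here means a stronger inhibitor, a higher number a weaker inhibitor. Compound 3 sits at the low end of this small set: it is far from compound 1, beyond the scatter, yet within the scatter of compound 2. Compound 4, `CCCCCCCCCCCSC[C@H](NC(C)=O)C(=O)CCl`, carries propyl in place of hydrogen on a saturated chain carbon, eight bonds along the chain from a sulfur. Two earlier steps bear on this change: a 12-fold lower number from compound 1 to compound 2 (1.10 log units; beyond the scatter), a large gain, and a 2.0-fold lower number from compound 2 to compound 3 (0.29 log units; within the scatter), a change within the scatter. Further lengthening is therefore expected to bring little, so the estimated step is a 1.4-fold lower number from compound 3 to compound 4 (0.14 log units; within the scatter). Compound 4 is expected to give about 3000 nM in this assay, between 1000 nM and 10000 nM.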

Compound 4, half-maximal inhibitory concentration: 3000 nM
Compound 4: the middle estimate sits on the measured number at the digits printed, within the range that was stated.
By their numbers in this assay, from the lowest: compounds 4, 3 and 2 (each within the scatter of the next, the first and the last beyond it); then compound 1.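

Propyl in place of hydrogen on a saturated chain carbon, eight bonds along the chain from a sulfur, gives only a small shift in this assay (a 1.4-fold lower number from compound 3 to compound 4 (0.14 log units; within the scatter)). This is the second step in a row within the scatter, so at this chain length, added carbons show no clear gain, unlike the large early step (a 12-fold lower number from compound 1 to compound 2 (1.10 log units; beyond the scatter)). Nothing available explains this levelling off.

From the compounds shown here alone, whether a still longer chain would stay level remains open, as does the effect of an amine or a carboxylic acid on the chain.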